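Swapping a Pyrazole for a Methylfuran

The source may hold more compounds than are shown below. What is called first, only, known or untested is meant among the compounds shown, and "the series" means these compounds.

Compound 3 `c1ccc(-c2cc[nH]n2)c(OCC2=NCCN2)c1` carries a 1H-pyrazol-3-yl group; in a functional assay with Alpha-1A adrenergic receptor (Homo sapiens) as the target, read by calcium flux (on this read-out higher numbers stand for larger maximal responses and lower numbers for smaller maximal responses), compound 3 gives 119%, the highest of the three numbers measured. Compound 1 `c1csc(-c2ccccc2OCC2=NCCN2)c1` gives 101%, and compound 2 `c1ccc(-c2ccoc2)c(OCC2=NCCN2)c1` gives 104%. Compound 4 `Cc1ccoc1-c1ccccc1OCC1=NCCN1` differs from compound 3 by 3-methylfuran-2-yl in place of 1H-pyrazol-3-yl on an aromatic carbon. For the measured compounds named here, two measured steps bear on this change: a number 18 percentage points higher from compound 1 to compound 3 (beyond the scatter) and a number 15 percentage points higher from compound 2 to compound 3 (beyond the scatter), both modest rises on entering the pyrazole. Bringing a furan-type ring back in place of the pyrazole is therefore expected to lower the maximal response by a modest amount, a number 15 percentage points lower from compound 3 to compound 4 (beyond the scatter). Compound 4 is thus estimated at 104% in this assay, within a range of 92% to 116%.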

Compound 4, largest response reached (reported as maximum), in percent of the reference or control that the assay uses: 99%
For compound 4 the middle estimate is 5 percentage points above the measured one; low and high end bracket the measured number.
By their numbers in this assay, from the lowest: compounds 4, 1 and 2 (each within the scatter of the next); then compound 3.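

In this assay, the 3-methylfuran-2-yl group falls in with the thiophen-2-yl and furan-3-yl groups, not with the pyrazole (a number 20 percentage points lower from compound 3 to compound 4 (beyond the scatter)). The other two steps stay within the scatter (a number 5 percentage points lower from compound 2 to compound 4 (within the scatter); a number 2 percentage points lower from compound 1 to compound 4 (within the scatter)). Of the four groups at this place, only the 1H-pyrazol-3-yl stands apart, and no measurement here accounts for that. Still open, from the compounds shown here alone, is whether an imidazole or a methyl-substituted pyrazole would match compound 3, which would show whether the hydrogen-bond donor of the pyrazole goes with the higher number.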